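The source may report more compounds than this note shows. Statements on the series, on what has been measured and on what is new or still open speak of the compounds shown alone.

Compound 1, `CCN1CCN(c2nc(C)c3cc(NC(=O)COc4ccc(Cl)cc4)ccc3n2)CC1`: in a functional assay on CHO-K1 cells for antagonist activity at melanin-concentrating hormone receptor 1 (Homo sapiens), read by inositol phosphate accumulation (a lower number here means a stronger inhibitor, a higher number a weaker inhibitor), compound 1 gives "not determined" (no result reported), that is, no result reported.
Compound 2, `Cc1nc(N2CCN(C)CC2)nc2ccc(NC(=O)COc3ccc(Cl)cc3)cc12`: in this assay compound 2 gives 3800 nM.
Compound 3, `CCC1(O)CCN(c2nc(C)c3cc(NC(=O)COc4ccc(Cl)cc4)ccc3n2)CC1`: in this assay compound 3 gives 384 nM.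

Among the compounds with values here, of the two numbers available, compound 3 holds the lower one; the only measured step is a 9.9-fold lower number from compound 2 to compound 3 (1.00 log units; beyond the scatter), which separates it from compound 2. Compound 4, `Cc1nc(N2CCN(CC(C)(C)C)CC2)nc2ccc(NC(=O)COc3ccc(Cl)cc3)cc12`, differs from compound 3 in one place: 4-neopentylpiperazin-1-yl in place of 4-ethyl-4-hydroxypiperidin-1-yl on an aromatic carbon. The change runs partly in reverse of the measured step, since compound 4 returns to a 4-substituted piperazin-1-yl ring like that of compound 2, while the alkyl on its far nitrogen is now neopentyl rather than methyl. Within the data shown here, no measured pair shows what a neopentyl group does here, so that part of the change is untested. Among the measured compounds shown here, on the single step available, a higher number than compound 3 is expected for compound 4, roughly a 3.9-fold higher number from compound 3 to compound 4 (0.59 log units; beyond the scatter). Compound 4 is therefore estimated at 1500 nM, within a range from 300 nM to 8000 nM.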

Compound 4, half-maximal inhibitory concentration: 246 nM
Compound 4: the middle estimate sits 6.1-fold (0.79 log units) above what was measured; the measured number lies below the stated range.
By their numbers in this assay, from the lowest: compounds 4 and 3 (each within the scatter of the next); then compound 2.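

The piperazin-1-yl ring does not by itself keep the number high at this position: with neopentyl rather than methyl on its far nitrogen, this assay shows a 15-fold lower number from compound 2 to compound 4 (1.19 log units; beyond the scatter), and this large step comes from adding tert-butyl in place of hydrogen on the chain carbon. The other comparison, a 1.6-fold lower number from compound 3 to compound 4 (0.19 log units; within the scatter), lies within the scatter, so 4-neopentylpiperazin-1-yl and 4-ethyl-4-hydroxypiperidin-1-yl cannot be told apart here. Only the latter carries a hydrogen-bond donor, so in this pair such a donor is not needed to reach this level.

As far as these compounds go, compound 1, with ethyl on that nitrogen, has no number, so the trend between methyl and neopentyl stays unknown, as does the outcome with a cyclohexyl group or a carboxylic acid there. No measurement shown explains why the group on that nitrogen matters so much.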